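The compounds below may be only part of what the source reports. "The series", "measured", "known", "first", "only" and "open" are said of these compounds alone.

Compound 1 `CC(C)Cc1ccc(-c2cn(C)c3cc(C(=O)NS(C)(=O)=O)ccc23)cc1`: 0.003
Compound 2 `CC(C)COc1ncc(-c2cn(C)c3cc(C(=O)NS(=O)(=O)C4CC4)c(F)cc23)cc1Cl`: 0.002
Compound 3 `CC(C)COc1ncc(-c2nn(C)c3cc(C(=O)NS(C)(=O)=O)ccc23)cc1Cl`: 0.002

In an ADME assay on a cell-free system (plasma, Mus musculus) for protein binding (a lower number here means a smaller unbound share, a higher number a larger unbound share of the compound), compound 2 gives 0.002 and stands level with compound 3 at 0.002 at the digits given, while compound 1 at 0.003 lies within the scatter of both. Compound 4 `CC(C)COc1ncc(-c2cn(C)c3cc(C(=O)NS(C)(=O)=O)c(F)cc23)cc1Cl` departs from compound 2 by methyl in place of cyclopropyl on a sulfonyl sulfur in the form of methyl in place of cyclopropyl on a sulfonyl sulfur. Going by the values given here, no measured pair isolates this change. In this assay compound 3, which also carries methylsulfonyl, gives 0.002 and so offers no sign of a larger shift. The expected 1.5-fold higher number from compound 2 to compound 4 (0.18 log units; within the scatter) stays within the scatter. The estimated value for compound 4 is 0.003 with an expected range from 0.0015 to 0.006 for this read-out.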

Compound 4, unbound fraction: 0.002
The estimate for compound 4 lay 1.5-fold (0.18 log units) above the measured number, within the range that was stated.
By their numbers in this assay, from the lowest: compounds 2, 3, 4 and 1 (each within the scatter of the next).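

Methyl in place of cyclopropyl on a sulfonyl sulfur gives no change at the digits printed from compound 2 to compound 4 (within the scatter) in this assay. This is the first pair among the compounds shown to isolate this change at this place, which the earlier compounds, differing from one another in more than one place, could not do. Nothing measured here accounts for the result.

The compounds shown leave open what a longer chain such as propyl, or an amine, on the sulfonyl sulfur would give in this assay. Also open, from the compounds shown here alone, is whether cyclopropyl and methyl would read alike on the core of compound 1 or compound 3.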